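Indole-oxadiazole series: methyl for 4-chlorophenyl

This account rests on a few compounds, and the source may have more. Where it says the series, first, only, none or still open, it means among the compounds named here.

Measured compounds:
- compound 1 `c1ccc2c(-c3nnc(-c4ccncc4)o3)c[nH]c2c1`; in a functional assay on MDA-MB-231 cells (Homo sapiens) for cytotoxicity, read by MTT assay (a higher number here means a weaker inhibitor, a lower number a stronger inhibitor), compound 1 gives > 1000000 nM, which is a limit of the assay and not a number.
- compound 2 `c1cncc(-c2nnc(-c3c[nH]c4ccccc34)o2)c1`; compound 2 gives > 1000000 nM, again a limit of the assay.
- compound 3 `Clc1ccc(-c2nnc(-c3c[nH]c4ccccc34)o2)cc1`; compound 3 gives > 1000000 nM, also a limit of the assay.

All three values sit at the limit of > 1000000 nM in this assay, at which 3 of the 3 values shown sit. For the measured compounds named here, the steps a step that the two limits leave unreadable from compound 1 to compound 2, a step that the two limits leave unreadable from compound 1 to compound 3 and a step that the two limits leave unreadable from compound 2 to compound 3 therefore give no readable size; nothing among the measured compounds distinguishes pyridin-4-yl, pyridin-3-yl or 4-chlorophenyl in this assay.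

Compound 4 `Cc1nnc(-c2c[nH]c3ccccc23)o1` differs from compound 3 by methyl in place of 4-chlorophenyl on an aromatic carbon. Going by the values given here, no measured step bears directly on this exchange, and the three unreadable steps give no direction. Since all measured values of the series, compound 3 included with > 1000000 nM, are limits, the expectation for compound 4 is that it also returns a limit rather than a number. The step that the limit leaves unreadable from compound 3 to compound 4 is thus expected to be none readable. Compound 4 is estimated at 1500000 nM, with a range from 300000 nM to 10000000 nM.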

Compound 4, half-maximal inhibitory concentration: > 1000000 nM
Compound 4 ended at the assay's limit; the forecaster's own chance of this, stated with the estimate: 85%; the middle value lies beyond the limit too.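

In this assay compound 4 gives > 1000000 nM as a limit of the assay and not a number. Its steps from compound 1, compound 2 and compound 3 therefore cannot be read: the limit of > 1000000 nM in this assay, at which 4 of the 4 values shown sit.

Going by these compounds, whether in this assay methyl, 4-chlorophenyl, pyridin-3-yl and pyridin-4-yl differ at all stays open.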